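The source may report more compounds than this note shows. Statements on the series, on what has been measured and on what is new or still open speak of the compounds shown alone.

Going by the values given here, compound 2 `O=C(/C=C/c1ccc(O)cc1)c1c(O)cccc1OCC1CCCC1` is the only member of the set with a number in a functional assay on ACHN cells (Homo sapiens) for antiproliferative activity, read by sulforhodamine B assay (on this read-out lower numbers stand for stronger inhibition of growth and higher numbers for weaker inhibition of growth), where compound 2 gives 3510 nM. Compound 1 `O=C(/C=C/c1ccc(O)cc1)c1c(O)cccc1OCc1ccccc1` reaches only a limit in this assay, > 30000 nM. Compound 3 `CC(C)(C)CCOc1cccc(O)c1C(=O)CCc1ccc(O)cc1` likewise stops at a limit in this assay, > 30000 nM. Among the compounds with values here, the one measured step at the same place is an at least 8.5-fold lower number from compound 1 to compound 2 (0.93 log units; beyond the scatter); it starts from the limit of > 30000 nM in this assay, at which 2 of the 3 values shown sit, so its true size is unknown. Compound 4 `CCC(CC)COc1cccc(O)c1C(=O)/C=C/c1ccc(O)cc1` differs from compound 2 by pentan-3-yl in place of cyclopentyl on a saturated chain carbon bound to an oxygen on an aromatic ring. Within the data shown here, no measured step swaps a carbocycle for a branched chain of the same count, so the change is expected to stay within the scatter or cost a little, a 1.4-fold higher number from compound 2 to compound 4 (0.15 log units; within the scatter). Compound 4 is therefore estimated at 5000 nM, within 1500 nM to 20000 nM.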

Compound 4, concentration for 50% growth inhibition: 3370 nM
Beside the measured number, compound 4's estimate is 1.5-fold (0.17 log units) above it; the range from low to high includes it.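

Opening the ring changes nothing measurable in this assay: a 1.0-fold lower number from compound 2 to compound 4 (0.02 log units; within the scatter), so at this place the branched pentan-3-yl serves as well as cyclopentyl, and a carbocycle is not required for the activity of this pair. The step of an at least 8.9-fold lower number from compound 1 to compound 4 (0.94 log units; beyond the scatter) shows a second saturated group outdoing phenyl, though its true size is unknown, as compound 1 stands at a limit: the limit of > 30000 nM in this assay, at which 2 of the 4 values shown sit.

On these data alone, whether a longer chain, or a terminal amine or carboxylic acid on the chain, would keep activity at this place remains open.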